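Activity of a cinnamate ester series in mice

A few compounds are considered here, and "the series" means these few. Any claim that something is new, unique, unknown or untested is made for them only; others in the source may bear on it.

Measured so far:
compound 1 `COc1cc(OC)c(OC)cc1/C=C/COC(=O)/C=C/c1ccc(OC)c(OC)c1` gives 100% in a functional assay on the whole organism (strain Kunming) with Mus musculus as the target, with a stated time of 0.5 h, at a dose of 100 mg/kg by the intraperitoneal route; on this read-out higher numbers stand for a weaker effect at the one dose given and lower numbers for a stronger effect
compound 2 `COc1cc(OC)c(OC)cc1/C=C/COC(=O)/C=C/c1cc(OC)c(OC)c(OC)c1` gives 100% in this assay

For the measured compounds named here, compound 1 stands level with compound 2 in this assay; the one step between them, no change at the digits printed from compound 1 to compound 2 (within the scatter), lies within the scatter. The next compound, compound 3 `COc1cc(OC)c(OC)cc1/C=C/COC(=O)/C=C/c1cccc(Br)c1`, is not yet measured. It differs from compound 1 in one place: 3-bromophenyl in place of 3,4-dimethoxyphenyl on a double-bonded chain carbon bound to a double-bonded chain carbon. Going by the values given here, no measured step bears directly on this change; the only step recorded, from compound 1 to compound 2, concerns a methoxy in place of hydrogen on an aromatic carbon and shows no change. On that basis the step from compound 1 to compound 3 is expected to stay within the scatter, no change at the digits printed from compound 1 to compound 3 (within the scatter). Compound 3 is therefore estimated at 100% in this assay, with a range from 80% to 100%.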

Compound 3, a percentage reported as activity, at one dose (the size of the read-out at that dose, not a potency): 100%
Compound 3: the middle estimate sits on the measured number at the digits printed; the range from low to high includes it.
By their numbers in this assay, from the lowest: compounds 1, 2 and 3 (each within the scatter of the next).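

In this assay, exchanging 3,4-dimethoxyphenyl for 3-bromophenyl on a double-bonded chain carbon bound to a double-bonded chain carbon gives no change at the digits printed from compound 1 to compound 3 (within the scatter). The earlier step added only a methoxy group, whereas this one replaces the whole aromatic group, removing both methoxy groups and bringing in a bromine, and the read-out still does not respond. Nothing measured here offers an explanation for this result.

All three compounds give the same reading and differ only in this aromatic group, so the compounds shown do not reveal whether any group at this place can move the read-out. On these data alone, an amine or a carboxylic acid on this aromatic ring, a longer chain in its place, or a change elsewhere in the shared core all remain open.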